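A few compounds are considered here, and "the series" means these few. Any claim that something is new, unique, unknown or untested is made for them only; others in the source may bear on it.

Working notes on the series. In an ADME assay on the whole organism for metabolic stability, with Rattus norvegicus as the target (on this read-out higher numbers stand for a longer-lived compound and lower numbers for a shorter-lived compound), compound 1 (`CCCS(=O)(=O)N1CCC(CNC(=O)C2CC2)(C(=O)N2CCOCC2)CC1`) gives 0.3 h, and compound 2 (`CCCS(=O)(=O)N1CCC(CNC(=O)c2c(F)cccc2F)(C(=O)N2CCOCC2)CC1`) gives 0.3 h, so compound 2 stands level with compound 1 at the precision available. The next structure is compound 3 (`CCCS(=O)(=O)N1CCC(CNC(=O)c2ccccc2Cl)(C(=O)N2CCOCC2)CC1`), which has 2-chlorophenyl in place of 2,6-difluorophenyl on a carbonyl carbon. For the measured compounds named here, one measured step bears on this change: no change at the digits printed from compound 1 to compound 2 (within the scatter), with 2,6-difluorophenyl in place of cyclopropyl on a carbonyl carbon. Going by the values given here, that evidence is thin, as it is a single pair, and no measured pair exchanges one substituted phenyl for another. Even so, the group on this carbonyl carbon has not yet moved the half-life beyond the scatter. On the strength of no change at the digits printed from compound 1 to compound 2 (within the scatter), no step beyond the scatter is expected in this assay, and neither direction is favoured. The expected result is no change at the digits printed from compound 2 to compound 3 (within the scatter). For compound 3 the estimated half-life is 0.3 h, with an expected range of 0.15 h to 0.6 h.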

Compound 3, half-life: 0.3 h
Compound 3: middle estimate and measured number agree at the digits printed; measured number inside the range.
By their numbers in this assay, from the lowest: compounds 1, 2 and 3 (each within the scatter of the next).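

Working notes, continued. In this assay, for the compounds shown here, exchanging one substituted phenyl for another at this position, with 2-chlorophenyl in place of 2,6-difluorophenyl on the carbonyl carbon, gives no change at the digits printed from compound 2 to compound 3 (within the scatter) and so supplies the pair the earlier compounds lacked. Set against cyclopropyl on the same carbonyl carbon, 2-chlorophenyl gives no change at the digits printed from compound 1 to compound 3 (within the scatter) and thereby joins 2,6-difluorophenyl as a second substituted phenyl that stands level with cyclopropyl. Across these three groups, then, the identity of the group on this carbonyl carbon has not moved the half-life beyond the scatter, and nothing at hand accounts for that flat result.

The three groups shown are cyclopropyl and two halogen-bearing phenyl rings, so it stays open whether a basic amine, a carboxylic acid or a longer alkyl chain on this carbonyl carbon would give a different half-life. From the compounds shown here alone, it also stays open whether the half-life responds to a change elsewhere in the shared core, since all three compounds differ only at this one place.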